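The source may report more compounds than this note shows. Statements on the series, on what has been measured and on what is new or still open speak of the compounds shown alone.

In a functional assay on CCRF-CEM cells (Homo sapiens) for antiproliferative activity, read by MTT assay, with a stated time of 48 h (a lower number here means that less compound is needed, a higher number that more compound is needed for the effect), compound 1 `COC(=O)c1[nH]c2cc(OC)ccc2c1C` reads > 100000 nM, which is a limit of the assay and not a number. Among the compounds with values here, compound 2 `COC(=O)c1[nH]c2cc(OC)ccc2c1C1CCCCC1` gives 80200 nM, the only actual number so far, so it cannot yet be ranked against another number. The next compound is compound 3 `COC(=O)c1[nH]c2cc(OC)ccc2c1Cc1ccccc1`, and the change is benzyl in place of cyclohexyl on an aromatic carbon. Within the data shown here, only one measured step touches this place, cyclohexyl in place of methyl on an aromatic carbon, and it gives little guidance on size. Among the measured compounds shown here, no step beyond the scatter is expected in this assay, in either direction, because an at least 1.2-fold lower number from compound 1 to compound 2 (0.09 log units; that floor lies within the scatter) is the only guide. The estimated step is a 1.1-fold lower number from compound 2 to compound 3 (0.06 log units; within the scatter). For compound 3 the expected value is 70000 nM, with an estimated range of 30000 nM to 100000 nM.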

Compound 3, half-maximal effective concentration: 8700 nM
The estimate for compound 3 lay 8.0-fold (0.91 log units) above the measured number; measured number below the stated range.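

In this assay, within the data shown here, the substituent on the aromatic carbon of the five-membered aromatic ring now clearly matters: benzyl in place of cyclohexyl gives a 9.2-fold lower number from compound 2 to compound 3 (0.96 log units; beyond the scatter), the first step between two actual numbers. Size alone does not set the read-out here, as the two groups differ by little in heavy atoms, while benzyl carries a six-membered aromatic ring where cyclohexyl carries a non-aromatic one; phenyl in place of hydrogen on the methyl carbon gives an at least 11-fold lower number from compound 1 to compound 3 (1.06 log units; beyond the scatter). That step is only a floor, since compound 1 stands at a limit of the assay and not a number: the limit of > 100000 nM in this assay, at which 1 of the 3 values shown sits.

Open, on these data alone, is whether the aromatic ring or its carbon link carries the change, which directly attached phenyl or a longer chain such as phenylethyl would separate. Also open, as far as these compounds go, is how an amine or a carboxylic acid on the benzyl ring would read.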